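The source may report more compounds than this note shows. Statements on the series, on what has been measured and on what is new or still open speak of the compounds shown alone.

Measured so far in a functional assay on aorta for antagonist activity at Alpha-1D adrenergic receptor (Rattus norvegicus); on this read-out higher numbers stand for weaker binding and lower numbers for tighter binding:
compound 1 `COc1ccccc1N1CCN(CCCNc2ncccc2C(=O)N(C)C)CC1` gives 20 nM
compound 2 `CN(C)C(=O)c1cccnc1NCCCN1CCN(c2ccccc2O)CC1` gives 63.1 nM
compound 3 `CN(C)C(=O)c1cccnc1NCCCN1CCN(c2ccccc2-c2ncco2)CC1` gives 25.1 nM

Compound 3 holds the second highest of these three numbers. Its nearest neighbour is compound 1, and the step of a 1.3-fold higher number from compound 1 to compound 3 (0.10 log units; within the scatter) lies within the scatter, so the two cannot be told apart. Compound 2 sits furthest away, and the step of a 2.5-fold lower number from compound 2 to compound 3 (0.40 log units; beyond the scatter) is beyond the scatter. Compound 4 `CC(C)c1ccccc1N1CCN(CCCNc2ncccc2C(=O)N(C)C)CC1` differs from compound 3 in one place: isopropyl in place of 1,3-oxazol-2-yl on an aromatic carbon.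

Going by the values given here, two measured steps touch this position. The step of a 1.3-fold higher number from compound 1 to compound 3 (0.10 log units; within the scatter) shows that methoxy and the 1,3-oxazol-2-yl ring give numbers within the scatter of each other, while the step of a 2.5-fold lower number from compound 2 to compound 3 (0.40 log units; beyond the scatter) shows that hydroxy gives a higher number than the ring. Among the compounds with values here, no measured compound carries isopropyl, so nothing closer than these two steps can guide the expectation. Because a 1.3-fold higher number from compound 1 to compound 3 (0.10 log units; within the scatter) stayed within the scatter when one group replaced another at this position, compound 4 is expected to land near compound 3 as well, with a wide band to cover the untested group. Compound 4 is therefore expected to show a step of a 1.2-fold higher number from compound 3 to compound 4 (0.08 log units; within the scatter) in this assay, none beyond the scatter. Compound 4 is estimated at 30 nM, within a range from 10 nM to 100 nM.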

Compound 4, dissociation constant: 63.1 nM
Beside the measured number, compound 4's estimate is 2.1-fold (0.32 log units) below it; the range from low to high includes it.
By their numbers in this assay, from the lowest: compounds 1 and 3 (each within the scatter of the next); then compounds 2 and 4 (each within the scatter of the next).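

Until now, methoxy and the 1,3-oxazol-2-yl ring could not be told apart at this aromatic carbon, so the position might have seemed to accept quite different groups; isopropyl shows that it does not accept every group equally in this assay, with a 2.5-fold higher number from compound 3 to compound 4 (0.40 log units; beyond the scatter) and with a 3.2-fold higher number from compound 1 to compound 4 (0.50 log units; beyond the scatter) as well. Isopropyl instead falls level with hydroxy, as no change at the digits printed from compound 2 to compound 4 (within the scatter) shows, so the four groups form two sets, methoxy with the ring and hydroxy with isopropyl, even though hydroxy holds an oxygen and isopropyl is carbon only. These compounds come with no separate data that could explain this split.

As far as these compounds go, whether a smaller carbon group such as methyl or ethyl would join isopropyl, or would stay with methoxy and the ring, remains open, and so does the result for a larger group such as tert-butyl. Also open, from the compounds shown here alone, is where an amine, a carboxylic acid or a six-membered ring such as pyridine would fall at this same aromatic carbon on the shared core.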